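Amine substituent swap from cyclohexylmethyl to cyclobutyl carboxamide

This account rests on a few compounds, and the source may have more. Where it says the series, first, only, none or still open, it means among the compounds named here.

Measured so far:
compound 1 `CO[C@H]1CC[C@H](CNc2cc(NCc3cnccc3C(F)(F)F)ncc2C#N)CC1` — > 10000 nM
compound 2 `N#Cc1cnc(NCc2ccccc2)cc1N[C@H]1CC[C@@H](O)CC1` — > 10000 nM
compound 3 `CC1(C)[C@@H](Nc2nc(NCc3cnccc3C(F)(F)F)ncc2C#N)C[C@@H]1O` — 2000 nM

In an assay on isolated protein for inhibition of protein kinase C delta type (Homo sapiens), read by TR-FRET, with a stated time of 2 h (a lower number here means a stronger inhibitor, a higher number a weaker inhibitor), compound 1 reports only a limit, > 10000 nM. Compound 2 likewise stops at the limit, > 10000 nM. Compound 3 gives a finite number, 2000 nM. Compound 1 therefore stands at the limit of > 10000 nM in this assay, at which 2 of the 3 values shown sit, and no finite value ranks it against compound 3.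

Compound 4 `CC1(C)[C@@H](Nc2cc(NCc3cnccc3C(F)(F)F)ncc2C#N)C[C@@H]1C(N)=O` awaits measurement in this assay. Relative to compound 1 the change is 3-carbamoyl-2,2-dimethylcyclobutyl in place of (4-methoxycyclohexyl)methyl on a nitrogen on an aromatic ring

Among the measured compounds shown here, no step between measured compounds is known. A move out of the limit into the measurable range is expected, so that for compound 4 the estimate is 3000 nM, spanning 700 nM to 10000 nM. This corresponds to an expected step of an at least 3.3-fold lower number from compound 1 to compound 4 (0.52 log units; beyond the scatter), beyond the scatter.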

Compound 4, half-maximal inhibitory concentration: > 10000 nM
Compound 4: only a limit was reported (the forecaster's own chance of this, stated with the estimate: 35%); middle value at least 3.3-fold (0.52 log units) from the limit.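

In this assay compound 1 and compound 4 each report only a limit, and no step can be read between them: the limit of > 10000 nM in this assay, at which 3 of the 4 values shown sit.

The compounds shown leave open how 3-carbamoyl-2,2-dimethylcyclobutyl compares with (4-methoxycyclohexyl)methyl on this nitrogen.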